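The source may hold more compounds than are shown below. What is called first, only, known or untested is meant among the compounds shown, and "the series" means these compounds.

Compound 1 `CN(C)C(=O)c1cc2cnc(Nc3ccc(NC(=O)C4(C(=O)Nc5ccc(F)cc5)CC4)cc3)nc2n1C1CCCC1` gives 102% in a functional assay on A549 cells (Homo sapiens) for inhibition, read by CCK-8 assay, with a stated time of 72 h, tested at 10 uM; on this read-out lower numbers stand for less inhibition of growth and higher numbers for more inhibition of growth at the one concentration tested.
Compound 2 `CN(C)C(=O)c1cc2cnc(Nc3ccc(NC(=O)C4(C(=O)Nc5cccc(Cl)c5)CC4)cc3)nc2n1C1CCCC1` gives 90.7% in this assay.
Compound 3 `CN(C)C(=O)c1cc2cnc(Nc3ccc(NC(=O)C4(C(=O)Nc5ccc(Cl)c(C(F)(F)F)c5)CC4)cc3)nc2n1C1CCCC1` gives 88.1% in this assay.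

Among these three, compound 1 has the highest value in this assay; compound 2 lies nearest to it and compound 3 furthest, both beyond the scatter. The unmeasured compound 4 `CN(C)C(=O)c1cc2cnc(Nc3ccc(NC(=O)C4(C(=O)Nc5cccc(Br)c5)CC4)cc3)nc2n1C1CCCC1` differs from compound 1 in one place: 3-bromophenyl in place of 4-fluorophenyl on an amide-type nitrogen.

For the measured compounds named here, two measured steps bear on this change. The step of a number 11.3 percentage points lower from compound 1 to compound 2 (beyond the scatter) swaps the same 4-fluorophenyl for another halogenated phenyl carrying its halogen in the 3-position, and the step of a number 13.9 percentage points lower from compound 1 to compound 3 (beyond the scatter) again replaces the 4-fluorophenyl with a phenyl bearing a 3-substituent. Both steps are modest losses in this assay and of similar size, while compound 2 and compound 3 lie within the scatter of each other, so the two ring replacements look alike in effect. Since 3-bromophenyl closely resembles 3-chlorophenyl, compound 4 is expected to follow the step from compound 1 to compound 2 rather than to stay level with compound 1.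

The expected step in this assay is therefore a number 11 percentage points lower from compound 1 to compound 4 (beyond the scatter), a modest decrease. Compound 4 is estimated to give 91% in this assay, within a range from 82% to 100%.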

Compound 4, percent growth inhibition at one concentration: 92.2%
Compound 4: the middle estimate sits 1.2 percentage points below what was measured; low and high end bracket the measured number.
By their numbers in this assay, from the lowest: compounds 3, 2, 4 and 1 (each within the scatter of the next, the first and the last beyond it).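

In this assay, bromo in place of chloro on an aromatic carbon gives a number 1.5 percentage points higher from compound 2 to compound 4 (within the scatter) and shows that this position accepts either halogen on the 3-halophenyl ring without a change that can be told from the scatter. 3-Bromophenyl in place of 4-chloro-3-(trifluoromethyl)phenyl gives a number 4.1 percentage points higher from compound 3 to compound 4 (within the scatter) and so places compound 2, compound 3 and compound 4 together, with no difference among these three rings on the amide-type nitrogen. 3-Bromophenyl in place of 4-fluorophenyl gives a number 9.8 percentage points lower from compound 1 to compound 4 (within the scatter) and, unlike the steps to compound 2 and compound 3, stays within the scatter, so the separation of compound 1 from the 3-substituted rings holds for only two of the three and is slight.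

Going by these compounds, whether an unsubstituted phenyl, a 4-bromophenyl, a pyridine ring or a saturated cyclohexyl group on the same nitrogen would keep these numbers remains open. With every number taken at a single concentration, it also remains open how these compounds would compare at lower concentrations, and nothing shown here accounts for the numbers at this position.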